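Ether in place of the furoate ester on the shared core

A few compounds are considered here, and "the series" means these few. Any claim that something is new, unique, unknown or untested is made for them only; others in the source may bear on it.

Compound 1 `CC(C)=CC[C@@H](OC(=O)c1ccco1)C1=CC(=O)c2c(O)ccc(O)c2C1=O`: 80300 nM
Compound 2 `CC(=O)OCCO[C@H](CC=C(C)C)C1=CC(=O)c2c(O)ccc(O)c2C1=O`: 41500 nM

Within the data shown here, in a functional assay on HeLa cells (Homo sapiens) for cytotoxicity, read by MTT assay (a higher number here means a weaker inhibitor, a lower number a stronger inhibitor), compound 1 stands at the high end of these two numbers, and its only neighbour is compound 2; the step of a 1.9-fold lower number from compound 1 to compound 2 (0.29 log units; within the scatter) is the one measured comparison. Compound 3 `CCC(CO[C@H](CC=C(C)C)C1=CC(=O)c2c(O)ccc(O)c2C1=O)OC` differs from compound 1 by 2-methoxybutyl in place of (furan-2-yl)carbonyl on an oxygen on a saturated carbon. That earlier step, which also exchanged the ester for an ether, bears on this change, so no step beyond the scatter is expected, with the estimate for compound 3 leaning slightly lower, as a 1.6-fold lower number from compound 1 to compound 3 (0.21 log units; within the scatter). Compound 3 is therefore estimated at 50000 nM, expected between 20000 nM and 125000 nM.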

Compound 3, half-maximal inhibitory concentration: 63500 nM
Compound 3: the middle estimate sits 1.3-fold (0.10 log units) below what was measured; low and high end bracket the measured number.
By their numbers in this assay, from the lowest: compounds 2, 3 and 1 (each within the scatter of the next).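

In this assay, 2-methoxybutyl in place of (furan-2-yl)carbonyl gives a 1.3-fold lower number from compound 1 to compound 3 (0.10 log units; within the scatter), and 1-methoxypropyl in place of acetoxymethyl gives a 1.5-fold higher number from compound 2 to compound 3 (0.18 log units; within the scatter). Compound 3 thus shows that the group on this oxygen can carry no ester at all and still stay within the scatter of both earlier compounds. Nothing available accounts for this.

As far as these compounds go, whether an amine or a carboxylic acid on this oxygen would move the number beyond the scatter remains open. So does the outcome with a much longer chain there.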